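The source may hold more compounds than are shown below. What is called first, only, known or untested is meant among the compounds shown, and "the series" means these compounds.

Compound 1 `Cc1c(N)c(C)c2c(c1CN1CCCCC1)OC(C)(C)C2`: > 50 mg/kg, a limit
Compound 2 `COC(=O)/C=C\C1(C)Cc2c(C)c(N)c(C)c(C)c2O1`: > 100 mg/kg, a limit
Compound 3 `CCOC(=O)Nc1c(C)c(C)c2c(c1C)CC(C)(C)O2`: > 100 mg/kg, a limit
Compound 4 `Cc1c(C)c2c(c(C)c1Nc1ccc(Cl)cc1)CC(C)(C)O2`: not yet measured

All readings so far come from a functional assay on the whole organism with Mus musculus as the target; on this read-out higher numbers stand for an effect only at larger amounts of compound and lower numbers for an effect already at smaller amounts. None of them is a number, so the measured compounds cannot be ranked against each other. Two limits describe the set: the limit of > 100 mg/kg in this assay, at which 2 of the 3 values shown sit, and (the limit of > 50 mg/kg in this assay, at which 1 of the 3 values shown sits).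

In this assay compound 3 gives > 100 mg/kg, which is a limit. Its place in the set is the limit of > 100 mg/kg in this assay, at which 2 of the 3 values shown sit.

The next step puts 4-chlorophenyl in place of ethoxycarbonyl on a nitrogen on an aromatic ring. For the measured compounds named here, no pair of measured compounds differs in one place only, so the series offers no measured step as a guide for this change. The expectation is therefore loose. In this assay a moderate move towards effect at smaller amounts is expected, with a substantial chance that compound 4 also reports only a limit. The estimated step is an at least 2.8-fold lower number from compound 3 to compound 4 (0.45 log units; beyond the scatter). The expected value for compound 4 is 35 mg/kg, with an estimated range from 8 mg/kg to 100 mg/kg.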

Compound 4, dose for 50% inhibition: > 50 mg/kg
Compound 4: only a limit was reported (the forecaster's own chance of this, stated with the estimate: 45%); at least 1.4-fold (0.15 log units) between middle value and limit.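

Compound 3 and compound 4 both stand only as limits in this assay, and the step between them cannot be read. The compounds shown leave open whether 4-chlorophenyl in place of ethoxycarbonyl on a nitrogen on an aromatic ring changes the dose needed in this assay, since none of the four compounds has a value that is a number.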